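Antiproliferative series: phenylethenyl in place of 2-chlorophenyl

A few compounds are considered here, and "the series" means these few. Any claim that something is new, unique, unknown or untested is made for them only; others in the source may bear on it.

Measured in a functional assay on HCT-15 cells (Homo sapiens) for antiproliferative activity, with a stated time of 48 h; on this read-out lower numbers stand for stronger inhibition of growth and higher numbers for weaker inhibition of growth:
compound 1 `Cc1cc(O)c(C2=NN(c3ccc(S(N)(=O)=O)cc3)C(c3ccccc3O)C2)cc1Cl` gives 3640 nM
compound 2 `Cc1cc(O)c(C2=NN(c3ccc(S(N)(=O)=O)cc3)C(c3ccccc3Cl)C2)cc1Cl` gives 3690 nM

Compound 2 stands highest of the two numbers, with compound 1 nearest; the step of a 1.0-fold higher number from compound 1 to compound 2 (0.01 log units; within the scatter) is within the scatter. Compound 3 `Cc1cc(O)c(C2=NN(c3ccc(S(N)(=O)=O)cc3)C(/C=C/c3ccccc3)C2)cc1Cl` differs from compound 2 by 2-phenylethenyl in place of 2-chlorophenyl on a saturated ring carbon. Going by the values given here, no measured step bears on this change: the single step known in this assay swaps hydroxy for chloro on an aromatic carbon, not the whole group on the saturated ring carbon. No shift beyond the scatter is therefore expected, but with a wide range. Compound 3 is expected to give 3500 nM in this assay, between 1000 nM and 12000 nM. The expected step is a 1.1-fold lower number from compound 2 to compound 3 (0.02 log units; within the scatter).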

Compound 3, concentration for 50% growth inhibition: 18900 nM
The estimate for compound 3 lay 5.4-fold (0.73 log units) below the measured number; measured number outside the range, above it.
By their numbers in this assay, from the lowest: compounds 1 and 2 (each within the scatter of the next); then compound 3.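

In this assay, the saturated ring carbon responds to a change of the whole group: 2-phenylethenyl in place of 2-chlorophenyl gives a 5.1-fold higher number from compound 2 to compound 3 (0.71 log units; beyond the scatter), and 2-phenylethenyl in place of 2-hydroxyphenyl gives a 5.2-fold higher number from compound 1 to compound 3 (0.72 log units; beyond the scatter). Both steps go towards weaker inhibition of growth, whereas the earlier swap of hydroxy for chloro on an aromatic carbon stayed within the scatter. No supporting data bear on the reason for this loss.

On these data alone, it remains open whether the double bond itself matters, which a saturated 2-phenylethyl group would test. As far as these compounds go, how an amine or a carboxylic acid on this carbon would read is also open.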